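Two Fluorines Out, One Ethoxy In on a Shared Core

The source may report more compounds than this note shows. Statements on the series, on what has been measured and on what is new or still open speak of the compounds shown alone.

Three compounds share one core. Compound 1 `Fc1cc(F)cc(Nc2nc3nonc3nc2Nc2cc(F)cc(F)c2)c1` and compound 2 `Fc1cc(C(F)(F)F)ccc1Nc1nc2nonc2nc1Nc1ccc(C(F)(F)F)cc1F` each carry two fluorine-bearing aromatic rings, as does compound 3 `Fc1ccc(Nc2nc3nonc3nc2Nc2ccccc2F)c(F)c1`. In an assay on mitochondria from L6 cells (Rattus norvegicus) for activation, with a stated time of 90 min (a higher number here means that more compound is needed for the effect, a lower number that less compound is needed), compound 1 gives < 1000 nM, which is a limit of the assay rather than a number. Compound 2 likewise gives < 1000 nM, again only a limit. For the measured compounds named here, compound 3 gives 300 nM, the only true number among the three, while the other two values sit at the limit of < 1000 nM in this assay, at which 2 of the 3 values shown sit. Compound 4 `CCOc1ccc(Nc2nc3nonc3nc2Nc2ccccc2F)cc1` has not been measured; it differs from compound 3 in one place: 4-ethoxyphenyl in place of 2,4-difluorophenyl on a nitrogen on an aromatic ring. Going by the values given here, no measured step shows what such a change does here, so only a modest shift toward more compound needed is expected, as a 1.7-fold higher number from compound 3 to compound 4 (0.22 log units; within the scatter). For compound 4 the estimate is 500 nM, between 100 nM and 2500 nM.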

Compound 4, half-maximal effective concentration: 3800 nM
Compound 4: the middle estimate sits 7.6-fold (0.88 log units) below what was measured, and the stated range ends below it.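

In this assay, for the compounds shown here, there is a 13-fold higher number from compound 3 to compound 4 (1.10 log units; beyond the scatter) when 4-ethoxyphenyl replaces 2,4-difluorophenyl on this nitrogen, the first measured step on the shared core. More compound is needed for the effect with the new ring, so the group at this place matters. The whole ring changes in one step, however, so the loss of both fluorines and the gain of the ethoxy cannot be told apart.

On these data alone, it remains open how a methoxy group, an amine or a carboxylic acid in place of the ethoxy would behave. Compound 1 and compound 2 add no numbers to this question, as each of their values is a limit: the limit of < 1000 nM in this assay, at which 2 of the 4 values shown sit.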